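The source may hold more compounds than are shown below. What is called first, only, known or untested is meant among the compounds shown, and "the series" means these compounds.

Measured so far in an assay on HEK293 cells for inhibition of N-acylethanolamine-hydrolyzing acid amidase (Homo sapiens), read by scintillation counting, tested at 50 uM; on this read-out lower numbers stand for less inhibition and higher numbers for more inhibition at the one concentration tested (going by the name of the read-out):
- compound 1 `CCCCCCCCCCCCCCCC(=O)Nc1ccc([N+](=O)[O-])cc1` gives 15%
- compound 2 `CCCCCCCCCCCCCCCCNC(=O)C1CCCC1` gives 8%
- compound 3 `CCCCCCCCCCCCCCCCOC(=O)C1CCCC1` gives 17%

Compound 3 shows the highest of the three numbers in this assay, yet its gaps to compound 1 and to compound 2 are both within the scatter, so no order among the three can be read. For the measured compounds named here, the only step between neighbouring compounds, a number 9 percentage points higher from compound 2 to compound 3 (within the scatter), also stayed within the scatter.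

Compound 4 `CCCCCCCCCCCCCCCCOC(=O)c1ccc(OC)cc1` has not yet been measured. It differs from compound 3 by 4-methoxyphenyl in place of cyclopentyl on a carbonyl carbon. No measured step alters the group on the carbonyl carbon, so nothing shown points to a direction; the one step known is small. Compound 4 is therefore expected to give an estimated step of no change at the digits printed from compound 3 to compound 4 (within the scatter), within the scatter. Compound 4 is estimated at 17%, ranging from 4% to 35%.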

Compound 4, a percentage reported as inhibition, at one concentration (the size of the read-out at that concentration, not a potency): "not active" (no number reported)
Compound 4: no number reported, so the estimate cannot be set against anything.
By their numbers in this assay, from the lowest: compounds 2, 1 and 3 (each within the scatter of the next).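

For the compounds shown here, compound 4 is reported only as "not active", without a number, so no step from compound 3 to compound 4 can be read. No evidence shown bears on this result. From the compounds shown here alone, what 4-methoxyphenyl in place of cyclopentyl does to inhibition remains open.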